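From compound 3 to compound 4: a longer saturated chain

The source may hold more compounds than are shown below. What is called first, only, known or untested is meant among the compounds shown, and "the series" means these compounds.

In an ADME assay on Vero cells (Chlorocebus sabaeus) for cytotoxicity, read by reporter gene assay, with a stated time of 4 days (on this read-out lower numbers stand for stronger inhibition and higher numbers for weaker inhibition), compound 1 `CCCCCC(=O)NCC(C)(C)CC1=C(O)C(=O)c2ccccc2C1=O` gives 46600 nM and compound 2 `CCCCCCCC(=O)NCC(C)(C)CC1=C(O)C(=O)c2ccccc2C1=O` gives 18400 nM while compound 3 `CCCCCCCCCCCC(=O)NCC(C)(C)CC1=C(O)C(=O)c2ccccc2C1=O` gives 13900 nM on the same read-out. Compound 3 therefore stands level with compound 2 within the scatter and clear of compound 1 beyond it.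

The change to compound 4 `CCCCCCCCCCCCCCCC(=O)NCC(C)(C)CC1=C(O)C(=O)c2ccccc2C1=O` is butyl in place of hydrogen on a saturated chain carbon, ten or more bonds along the chain from a carbonyl carbon and it leaves the shared core untouched. The same butyl replacement, made seven bonds along the chain from a carbonyl carbon, gave a 1.3-fold lower number from compound 2 to compound 3 (0.12 log units; within the scatter) and so stayed within the scatter. Modest and beyond the scatter were a 2.5-fold lower number from compound 1 to compound 2 (0.40 log units; beyond the scatter) and a 3.4-fold lower number from compound 1 to compound 3 (0.53 log units; beyond the scatter) in the same direction. Among the measured steps, only those starting from compound 1 clear the scatter.

Compound 4 is therefore expected to stay close to compound 3, with at most a small drift towards a lower number and no step beyond the scatter. The estimated step is a 1.3-fold lower number from compound 3 to compound 4 (0.10 log units; within the scatter) on this reasoning. In this assay compound 4 is estimated at 11000 nM with an expected range from 5000 nM to 24000 nM around that middle.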

Compound 4, half-maximal inhibitory concentration: 5600 nM
Compound 4: middle estimate off by 2.0-fold (0.29 log units), on the high side; measured number inside the range.
By their numbers in this assay, from the lowest: compound 4; then compounds 3 and 2 (each within the scatter of the next); then compound 1.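

Butyl in place of hydrogen on a saturated chain carbon gives a 2.5-fold lower number from compound 3 to compound 4 (0.39 log units; beyond the scatter) in this assay, whereas the same replacement seven bonds along the chain gave only a 1.3-fold lower number from compound 2 to compound 3 (0.12 log units; within the scatter), so the chain still affects the read-out at this length and the earlier flattening did not hold. Among the compounds shown here, compound 4 is the only compound whose steps to all the others lie beyond the scatter, with a 3.3-fold lower number from compound 2 to compound 4 (0.52 log units; beyond the scatter) and an 8.3-fold lower number from compound 1 to compound 4 (0.92 log units; beyond the scatter) added to the step above, so across these four compounds the number falls as the saturated chain grows, with the pair of compound 2 and compound 3 as the one exception that does not separate. Nothing available here bears on what lies behind this fall.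

The compounds shown leave open whether a longer chain would lower the number further or whether the trend ends near compound 4. They also leave open how a chain ending in an amine or a carboxylic acid would read at this position.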